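Acetyl pair: 4-chlorophenyl to 3,4-dimethoxyphenyl

A few compounds are considered here, and "the series" means these few. Any claim that something is new, unique, unknown or untested is made for them only; others in the source may bear on it.

In a functional assay on PC-3 cells (Homo sapiens) for cytotoxicity, read by MTT assay, with a stated time of 48 h (on this read-out higher numbers stand for weaker inhibition and lower numbers for stronger inhibition), compound 1 `COc1cc(NC(=O)n2cc(-c3ccc(O)cc3)n(-c3cc(OC)c(OC)c(OC)c3)c2=O)cc(OC)c1OC` gives 3000 nM.

Compound 2 `COc1ccc(-c2cn(C(=O)Nc3cc(OC)c(OC)c(OC)c3)c(=O)n2-c2cc(OC)c(OC)c(OC)c2)cc1O` reads > 50000 nM, which is a limit and not a number.

The weak end of the scale so far is the limit of > 50000 nM in this assay, at which 1 of the 3 values shown sits.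

Compound 3 `COc1cc(-n2c(-c3ccc(Cl)cc3)cn(C(C)=O)c2=O)cc(OC)c1OC` has no place on this scale, its entry being "not determined" (no result reported).

The change to compound 4 `COc1ccc(-c2cn(C(C)=O)c(=O)n2-c2cc(OC)c(OC)c(OC)c2)cc1OC` is 3,4-dimethoxyphenyl in place of 4-chlorophenyl on an aromatic carbon.

Within the data shown here, one measured step bears on this, and only loosely. It is an at least 16-fold higher number from compound 1 to compound 2 (1.22 log units; beyond the scatter), large and beyond the scatter, with 3-hydroxy-4-methoxyphenyl in place of 4-hydroxyphenyl on an aromatic carbon. Neither of its compounds carries the acetyl group of compound 3, and compound 3 has no number to step from, so no size of step can be expected for this pair. That single step points only towards higher numbers, so compound 4 is expected to sit on the weak side of the scale, possibly at the limit.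

For compound 4 the estimated value in this assay is 20000 nM, with an expected range of 3000 nM to 50000 nM.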

Compound 4, half-maximal inhibitory concentration: > 50000 nM
Compound 4: a limit, no number; the forecaster's own chance of this, stated with the estimate: 40%; at least 2.5-fold (0.39 log units) between middle value and limit.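

No step can be read from compound 3 to compound 4 in this assay, since the entry for compound 3 holds no number and the entry for compound 4 is a limit. The compounds shown leave open how 3,4-dimethoxyphenyl compares with 4-chlorophenyl in this acetyl pair.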